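This account rests on a few compounds, and the source may have more. Where it says the series, first, only, none or still open, it means among the compounds named here.

Measured in a functional assay on isolated protein for inhibition of Glucose-dependent insulinotropic receptor (Rattus norvegicus), read by HTRF and cAMP accumulation; a lower number here means that less compound is needed, a higher number that more compound is needed for the effect:
compound 1, `Cc1nc(S(C)(=O)=O)ccc1Oc1ncnc(OC2CCN(C(=O)OC(C)C)CC2)c1F`, gives 142 nM
compound 2, `Cc1nc(S(C)(=O)=O)ccc1Oc1ncnc(OC2CCN(C(=O)OC(C)(C)CF)CC2)c1F`, gives 138 nM
compound 3, `Cc1nc(S(C)(=O)=O)ccc1Oc1ncnc(OC2CCN(C(=O)O[C@H](C)CF)CC2)c1F`, gives 1520 nM

Compound 2 gives the lowest of these three numbers, but the step of a 1.0-fold lower number from compound 1 to compound 2 (0.01 log units; within the scatter) is within the scatter, so compounds 1 and 2 cannot be ranked against each other. Compound 3 stands apart: an 11-fold higher number from compound 2 to compound 3 (1.04 log units; beyond the scatter), and likewise an 11-fold higher number from compound 1 to compound 3 (1.03 log units; beyond the scatter).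

Compound 4 is `CCC(F)(F)C(=O)N1CCC(Oc2ncnc(Oc3ccc(S(C)(=O)=O)nc3C)c2F)CC1`. Compared with compound 2 the change is a group of 5 heavy atoms (3 carbon, 2 fluorine; no ring) in place of a group of 6 heavy atoms (4 carbon, 1 oxygen, 1 fluorine; no ring), on a carbonyl carbon. Within the data shown here, no measured step exchanges the group on the carbonyl carbon in this way, so none bears on it directly. The nearest steps vary the group on the oxygen of that carbonyl: the small step of a 1.0-fold lower number from compound 1 to compound 2 (0.01 log units; within the scatter) shows that one change there costs nothing, while the large step of an 11-fold higher number from compound 2 to compound 3 (1.04 log units; beyond the scatter) shows that another change there costs much. The change to compound 4 is larger than either, so a step beyond the scatter toward a higher number is expected, with wide uncertainty, as a 3.3-fold higher number from compound 2 to compound 4 (0.51 log units; beyond the scatter). Compound 4 is therefore estimated at 450 nM, within a range from 120 nM to 2000 nM.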

Compound 4, half-maximal effective concentration: 69.2 nM
Compound 4: middle estimate off by 6.5-fold (0.81 log units), on the high side; the measured number lies below the stated range.
By their numbers in this assay, from the lowest: compounds 4, 2 and 1 (each within the scatter of the next, the first and the last beyond it); then compound 3.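

In this assay, the carbonyl carbon on the amide-type nitrogen in a ring proves to tolerate a group that has no oxygen: 1,1-difluoropropyl gives a 2.0-fold lower number from compound 2 to compound 4 (0.30 log units; within the scatter). Against isopropoxy, the same exchange gives a 2.1-fold lower number from compound 1 to compound 4 (0.31 log units; beyond the scatter), a modest step and the first change here to reach a lower number than compound 1 beyond the scatter. The step of a 22-fold lower number from compound 3 to compound 4 (1.34 log units; beyond the scatter) shows that two fluorine-bearing groups with the same heavy-atom count can end far apart at this place.

No measurement shown accounts for these differences. As far as these compounds go, whether the fluorines of 1,1-difluoropropyl matter, as a plain propyl chain would test, and how a longer chain or an amine would fare on this carbonyl carbon, remain open.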